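Swapping a flexible amine tail for a piperidine ester

A few compounds are considered here, and "the series" means these few. Any claim that something is new, unique, unknown or untested is made for them only; others in the source may bear on it.

Of the compounds shown here, three built on one shared core have been measured in an assay on isolated protein (Cavia porcellus) with Sigma non-opioid intracellular receptor 1 (Homo sapiens) as the target, read by radioligand binding; on this read-out lower numbers stand for stronger inhibition and higher numbers for weaker inhibition. Compound 1 `CN(C)CCCCOc1ccc2oc(-c3ccccc3)cc(=O)c2c1` gives 400 nM. Compound 2 `CN(C)CCCCCCCCCCOc1ccc2oc(-c3ccccc3)cc(=O)c2c1` gives 341 nM. Compound 3 `O=c1cc(-c2ccccc2)oc2ccc(OCCCN3CCC(O)CC3)cc12` gives 123 nM. Among these, compound 2 stands second highest of the three numbers: it sits close to compound 1, a 1.2-fold lower number from compound 1 to compound 2 (0.07 log units; within the scatter), while the gap to compound 3 is larger, a 2.8-fold lower number from compound 2 to compound 3 (0.44 log units; beyond the scatter).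

The unmeasured compound 4 `CCOC(=O)C1CCN(CCCCCCOc2ccc3oc(-c4ccccc4)cc(=O)c3c2)CC1` differs from compound 2 by one change: 4-(ethoxycarbonyl)piperidin-1-yl in place of 4-(dimethylamino)butyl on a saturated chain carbon, six bonds along the chain from an oxygen on an aromatic ring. In words, a ring-bearing amine takes the place of an open dimethylamino chain.

Within the data shown here, two measured steps bear on this. Each replaced an open dimethylamino chain with a piperidine ring: a 3.3-fold lower number from compound 1 to compound 3 (0.51 log units; beyond the scatter) and a 2.8-fold lower number from compound 2 to compound 3 (0.44 log units; beyond the scatter). Both moved beyond the scatter in the same direction, toward lower numbers, though the ring in compound 3 carries a hydroxy group, whereas compound 4 carries an ethoxycarbonyl group and a longer linker, so the match is loose.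

On this basis a modest move toward a lower number is expected, a 2.6-fold lower number from compound 2 to compound 4 (0.42 log units; beyond the scatter). Compound 4 is therefore estimated at 130 nM, within a range from 40 nM to 400 nM in this assay.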

Compound 4, half-maximal inhibitory concentration: 102 nM
Estimate against measurement, compound 4: 1.3-fold (0.11 log units) above; low and high end bracket the measured number.
By their numbers in this assay, from the lowest: compounds 4 and 3 (each within the scatter of the next); then compounds 2 and 1 (each within the scatter of the next).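

In this assay the swap of the open tail for the ring ester gives a 3.3-fold lower number from compound 2 to compound 4 (0.52 log units; beyond the scatter) and so shows that a lower number at this end of the molecule is not tied to the hydroxy-bearing ring of compound 3. It also shows that this place, six bonds along the chain from an oxygen on an aromatic ring, accepts a clearly larger group without any rise in the number: 4-(ethoxycarbonyl)piperidin-1-yl brings 11 heavy atoms, a six-membered ring and 3 hydrogen-bond acceptors, where 4-(dimethylamino)butyl had 7 heavy atoms, no ring and 1 acceptor. No measurement at hand explains why the number falls with this change.

This single step alters the ring, the ester and the open chain together, so the part each plays stays unresolved. Plain piperidin-1-yl on the same chain would test the ring alone, while a carboxylic acid or a primary amide in place of the ethyl ester would test whether the ester itself matters.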